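Methoxy for bromo on the aryl ring: compound 3

The compounds below may be only part of what the source reports. "The series", "measured", "known", "first", "only" and "open" are said of these compounds alone.

Measured compounds:
compound 1 `O=C(Nc1ccc(Oc2ccnc3[nH]ccc23)c(F)c1)c1cc2cccnc2n(-c2ccc(Cl)cc2)c1=O` — 110 nM
compound 2 `O=C(Nc1ccc(Oc2ccnc3[nH]ccc23)c(F)c1)c1cc2cccnc2n(-c2ccc(Br)cc2)c1=O` — 210 nM

In a functional assay on A549 cells (Homo sapiens) for antiproliferative activity, read by MTT assay, with a stated time of 72 h (a lower number here means a stronger inhibitor, a higher number a weaker inhibitor), compound 1 gives 110 nM and compound 2 gives 210 nM. Compound 2 holds the higher of the two numbers, but the step of a 1.9-fold higher number from compound 1 to compound 2 (0.28 log units; within the scatter) lies within the scatter, so the two compounds cannot be ranked against each other.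

Compound 3 `COc1ccc(-n2c(=O)c(C(=O)Nc3ccc(Oc4ccnc5[nH]ccc45)c(F)c3)cc3cccnc32)cc1` differs from compound 2 by methoxy in place of bromo on an aromatic carbon. Among the compounds with values here, only one measured step exists, a 1.9-fold higher number from compound 1 to compound 2 (0.28 log units; within the scatter), and it exchanges one halogen for another at the same place; no measured compound carries methoxy on that ring. That step stayed within the scatter, so the numbers give no ground to expect a step beyond the scatter in this assay for the present exchange. Compound 3 is therefore expected at 200 nM, with a range from 70 nM to 600 nM. The expected step of a 1.1-fold lower number from compound 2 to compound 3 (0.02 log units; within the scatter) stays within the scatter.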

Compound 3, half-maximal inhibitory concentration: 610 nM
Estimate against measurement, compound 3: 3.1-fold (0.48 log units) below, and the stated range ends below it.
By their numbers in this assay, from the lowest: compounds 1 and 2 (each within the scatter of the next); then compound 3.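

In this assay, the para substituent on this aryl ring proved able to move the number, which the halogen exchange alone could not show (a 1.9-fold higher number from compound 1 to compound 2 (0.28 log units; within the scatter)). Methoxy in place of bromo gives a step beyond the scatter (a 2.9-fold higher number from compound 2 to compound 3 (0.46 log units; beyond the scatter)), and methoxy in place of chloro gives a somewhat larger one (a 5.5-fold higher number from compound 1 to compound 3 (0.74 log units; beyond the scatter)), so the 4-methoxyphenyl compound 3 separates from both halogen compounds, although the steps remain modest. No available evidence bears on the origin of this difference.

The compounds shown leave open whether this higher number is particular to methoxy or extends to other non-halogen groups at the same place. A 4-aminophenyl or 4-ethoxyphenyl ring would test this, and a 4-fluorophenyl ring would test whether the halogen result extends further.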